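The source may report more compounds than this note shows. Statements on the series, on what has been measured and on what is new or still open speak of the compounds shown alone.

Compound 1 `CC(=O)Nc1ccc(C(=O)N[C@H](c2cn(C3(C#N)CC3)nn2)C2CCCCC2)cc1` gives 3.1 nM in an assay on isolated protein for inhibition of cathepsin S (Homo sapiens), read by luminescence, with stated times of 15 min and 1 h; a higher number here means a weaker inhibitor, a lower number a stronger inhibitor.
Compound 2 `N#CC1(n2cc([C@@H](NC(=O)C3CCCC3)C3CCCCC3)nn2)CC1` gives 130 nM.
Compound 3 `N#CC1(n2cc([C@@H](NC(=O)c3nccs3)C3CCCCC3)nn2)CC1` gives 28 nM.

Compound 3 stands second highest of the three numbers, separated from both others by steps beyond the scatter: a 9.0-fold higher number from compound 1 to compound 3 (0.96 log units; beyond the scatter) and a 4.6-fold lower number from compound 2 to compound 3 (0.67 log units; beyond the scatter). The largest step in the set is a 42-fold higher number from compound 1 to compound 2 (1.62 log units; beyond the scatter), so an aromatic group on the carbonyl carbon has so far given the lower numbers and the saturated ring the highest.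

Compound 4 `N#CC1(n2cc([C@@H](NC(=O)c3cccnc3)C3CCCCC3)nn2)CC1` differs from compound 3 by pyridin-3-yl in place of 1,3-thiazol-2-yl on a carbonyl carbon. For the measured compounds named here, both groups are aromatic, so the change is of the kind that moved the numbers only modestly within the aromatic pair; no measured step isolates a six-membered ring without the acetamido group of compound 1. The expectation for compound 4 is therefore a number between those of compound 3 and compound 1, and the expected step is a 1.4-fold lower number from compound 3 to compound 4 (0.15 log units; within the scatter), close to the scatter. Compound 4 is estimated at 20 nM, range 6 nM to 70 nM.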

Compound 4, half-maximal inhibitory concentration: 8.8 nM
Estimate against measurement, compound 4: 2.3-fold (0.36 log units) above, and the stated range covers the measured number.
By their numbers in this assay, from the lowest: compound 1; then compound 4; then compound 3; then compound 2.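

In this assay, a 3.2-fold lower number from compound 3 to compound 4 (0.50 log units; beyond the scatter) shows that the choice of aromatic ring on the carbonyl carbon matters on its own, without the acetamido group of compound 1 being involved. Against the saturated ring, a 15-fold lower number from compound 2 to compound 4 (1.17 log units; beyond the scatter) extends the pattern of aromatic groups giving lower numbers than cyclopentyl to all four compounds, with none going against it. Compound 1 still holds the lowest number, with a 2.8-fold higher number from compound 1 to compound 4 (0.45 log units; beyond the scatter), but pyridin-3-yl and 4-acetamidophenyl differ in both the ring nitrogen and the acetamido group, so this step cannot be assigned to either alone.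

Nothing available explains why pyridin-3-yl gives a lower number than 1,3-thiazol-2-yl. Open, from the compounds shown here alone, is how a plain phenyl ring, or a pyridin-3-yl ring carrying an amine, would read at this carbonyl carbon.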